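Shortening the Octyl Chain to Hexyl

The source may hold more compounds than are shown below. What is called first, only, known or untested is meant among the compounds shown, and "the series" means these compounds.

Compound 1 `CC(=O)Nc1nc(-c2cccc(NS(=O)(=O)c3ccc(C#CCCc4ccccc4)cc3)c2)cs1` and compound 2 `CCCCCCCCc1ccc(S(=O)(=O)Nc2cccc(-c3csc(NC(C)=O)n3)c2)cc1` share one core. In a functional assay on A-375 cells (Homo sapiens) for antiproliferative activity, read by trypan blue exclusion, with a stated time of 48 h, tested at 5 uM (on this read-out lower numbers stand for a stronger effect and higher numbers for a weaker effect at the one concentration tested), compound 1 gives 4.2%. Compound 2 reaches only a limit of this assay, < 1% (the limit of < 1% in this assay, at which 1 of the 2 values shown sits). Among the compounds with values here, the single measured step is a number at least 3.2 percentage points lower from compound 1 to compound 2 (that floor lies within the scatter), which does not reach beyond the scatter. Compound 3 `CCCCCCc1ccc(S(=O)(=O)Nc2cccc(-c3csc(NC(C)=O)n3)c2)cc1` differs from compound 2 by hydrogen in place of ethyl on a saturated chain carbon, six bonds along the chain from an aromatic carbon. Within the data shown here, no measured step covers this change, so no movement beyond the scatter is expected in either direction. A step of a number at least 1 percentage points higher from compound 2 to compound 3 (that floor lies within the scatter) is expected. Compound 3 is therefore estimated at 2%, within a range from 0.5% to 8%.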

Compound 3, a percentage reported as activity, at one concentration (the size of the read-out at that concentration, not a potency): < 1%
Compound 3 was reported as a limit; the forecaster's own chance of this, stated with the estimate: 45%; middle value at least 1 percentage points away from the limit.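

In this assay compound 3 reaches a limit of the assay, < 1%. Hexyl in place of octyl therefore leaves the read-out at the limit, and the step between compound 2 and compound 3 cannot be read because both sit there: the limit of < 1% in this assay, at which 2 of the 3 values shown sit. The change from 4-phenylbut-1-yn-1-yl to hexyl gives a number at least 3.2 percentage points lower from compound 1 to compound 3 (that floor lies within the scatter).

The compounds shown leave open whether a butyl chain would still stay at this limit. They also leave open what an amine or a carboxylic acid in place of the chain would do.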